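Removing the chloro from the anilino ring of compound 1

This account rests on a few compounds, and the source may have more. Where it says the series, first, only, none or still open, it means among the compounds named here.

Measured so far in a functional assay on NCI-H460 cells (Homo sapiens) for cytotoxicity, read by MTT assay; on this read-out lower numbers stand for stronger inhibition and higher numbers for weaker inhibition:
compound 1, `COc1cc(/C=C/C(=O)c2sc(Nc3ccc(Cl)cc3)nc2C)cc(OC)c1OC`, gives 22000 nM.
compound 2, `Cc1ccccc1Nc1nc(C)c(C(=O)/C=C/c2ccc(Cl)cc2)s1`, gives > 25000 nM, which is a limit of the assay and not a number.
compound 3, `Cc1nc(Nc2ccc(Cl)cc2)sc1C(=O)/C=C/c1ccc(Cl)cc1`, gives > 25000 nM, likewise a limit and not a number.

Within the data shown here, compound 1 thus holds the only number; the other two values sit at the limit of > 25000 nM in this assay, at which 2 of the 3 values shown sit. The step that the two limits leave unreadable from compound 2 to compound 3 cannot be read because both of its values sit at the limit of > 25000 nM in this assay, at which 2 of the 3 values shown sit.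

Compound 4, `COc1cc(/C=C/C(=O)c2sc(Nc3ccccc3)nc2C)cc(OC)c1OC`, differs from compound 1 by hydrogen in place of chloro on an aromatic carbon, para to a large group, or read one bond further out, 4-chlorophenyl to phenyl on a nitrogen on an aromatic ring. Among the measured compounds shown here, no measured step touches this change. For the measured compounds named here, the only measured step exchanges the whole aryl group on that nitrogen and is unreadable, so nothing sets a size for the loss of the chloro. The expectation for compound 4 in this assay is therefore a step of a 1.3-fold higher number from compound 1 to compound 4 (0.10 log units; within the scatter), not beyond the scatter, with a real chance that only the limit is returned. Compound 4 is estimated at 28000 nM, between 12000 nM and 70000 nM.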

Compound 4, half-maximal inhibitory concentration: > 25000 nM
Compound 4: only a limit was reported (the forecaster's own chance of this, stated with the estimate: 55%); the middle value does not contradict the limit.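

Among these compounds, exchanging chloro for hydrogen on the anilino ring, a change that no earlier step touched, now has a reading in this assay: an at least 1.1-fold higher number from compound 1 to compound 4 (0.05 log units; that floor lies within the scatter). Compound 4 gives > 25000 nM, which is a limit of the assay and not a number. The result therefore sets only a floor, and that floor lies within the scatter: hydrogen at this place brings no measurable value into the series, compound 1 keeps the only number, and the series now rests mostly on one limit: the limit of > 25000 nM in this assay, at which 3 of the 4 values shown sit.

The compounds shown leave open how far the true value of compound 4 lies beyond its limit, and with it whether the chloro counts for anything at this place on the ring. They also leave open whether an amine or a carboxylic acid in the same place, on the core of compound 1, would give a number clearly apart from the limit, which is the kind of reading needed to set a size for changes at this position.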